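Aryl ether versus biaryl at the fused-ring position

This account rests on a few compounds, and the source may have more. Where it says the series, first, only, none or still open, it means among the compounds named here.

Measured so far in an ADME assay on HepG2 cells (Homo sapiens) for cytotoxicity, read by luminescence, CellTiter-Glo and ATP content, with a stated time of 72 h; a lower number here means that less compound is needed, a higher number that more compound is needed for the effect:
- compound 1 `COc1cccc(CNCCCNc2ccnc3cc(Oc4ccccc4)ccc23)c1O`: 6800 nM
- compound 2 `Cc1cc(C)cc(Cc2ccc3c(NCCCNCc4ccco4)ccnc3c2)c1`: 6270 nM
- compound 3 `COc1cccc(CNCCCNc2ccnc3cc(-c4ccc(C(C)(C)C)cc4)ccc23)c1O`: 690 nM

Compound 3 gives the lowest number of the three in this assay; compound 2 and compound 1 both sit well beyond the scatter from it, compound 1 furthest. Within the data shown here, the one single-point step available is a 9.9-fold lower number from compound 1 to compound 3 (0.99 log units; beyond the scatter), an aryl ether exchanged for a biaryl on the shared core.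

Compound 4 `COc1cccc(Oc2ccc3c(NCCCNCc4cccc(OC)c4O)ccnc3c2)c1` differs from compound 3 by 3-methoxyphenoxy in place of 4-(tert-butyl)phenyl on an aromatic carbon. This change largely reverses the step from compound 1 to compound 3, returning an aryl ether at the same place, with a methoxy added on the entering ring. Among the measured compounds shown here, the step from compound 1 to compound 3 is the only measured step that bears on it, and it was modest but beyond the scatter; the expectation is therefore a step of comparable size in the opposite direction, toward the value of compound 1. For the measured compounds named here, no measured compound shows what the added methoxy on the phenoxy ring does, so that part is taken as neutral.

Compound 4 is accordingly expected near 5000 nM, in the range 1500 nM to 15000 nM, an estimated step of a 7.2-fold higher number from compound 3 to compound 4 (0.86 log units; beyond the scatter).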

Compound 4, half-maximal effective concentration: 5300 nM
Estimate against measurement, compound 4: 1.1-fold (0.03 log units) below, within the range that was stated.
By their numbers in this assay, from the lowest: compound 3; then compounds 4, 2 and 1 (each within the scatter of the next).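

In this assay the exchange of 4-(tert-butyl)phenyl for 3-methoxyphenoxy gives a 7.7-fold higher number from compound 3 to compound 4 (0.89 log units; beyond the scatter) and so shows the gap between biaryl and aryl ether a second time, now with a different ether. Methoxy in place of hydrogen on the phenoxy ring gives a 1.3-fold lower number from compound 1 to compound 4 (0.11 log units; within the scatter) and stays within the scatter, so this substitution has no readable effect in this pair. Across compound 1, compound 3 and compound 4, the two aryl ethers therefore stand together and apart from the biaryl, a pattern that rests on these three compounds alone.

No measurement here accounts for these numbers. Still open, from the compounds shown here alone, is whether the lower number of compound 3 belongs to the directly attached aryl ring or to its tert-butyl group, which a plain phenyl or a phenyl bearing a carboxylic acid at this place would help to separate.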